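This account rests on a few compounds, and the source may have more. Where it says the series, first, only, none or still open, it means among the compounds named here.

Of the compounds shown here, two built on a shared core have so far been tested in a functional assay on HFF cells (Homo sapiens) for inhibition; a lower number here means a stronger inhibitor, a higher number a weaker inhibitor. Compound 1, `CSc1nc2cnsc2n1[C@H]1C[C@H](O)[C@@H](CO)O1`, reaches only the limit of the assay: in this assay compound 1 gives > 100000 nM, a limit and not a number. Compound 2, `CSc1nc2c(C)nsc2n1[C@@H]1O[C@H](CO)[C@@H](O)[C@H]1O`, is no different in kind: in this assay compound 2 gives > 100000 nM, again a limit of the assay rather than a measured value. Within the data shown here, compound 2 therefore stands where every value so far stands, at the limit of > 100000 nM in this assay, at which 2 of the 2 values shown sit, and no step between measured compounds can be drawn from this set.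

Compound 3, `CSc1nc2cnsc2n1[C@@H]1O[C@H](CO)[C@@H](O)[C@H]1O`, has not yet been measured in this assay. It differs from compound 2 by hydrogen in place of methyl on an aromatic carbon. Among the measured compounds shown here, with both known values sitting at a limit, there is no measured step from which to judge the size of this change. The expected step that the limit leaves unreadable from compound 2 to compound 3 is none beyond the scatter, and the likeliest outcome is that the assay again reports only a limit. Compound 3 is thus estimated at about 200000 nM, within a range from 50000 nM to 1000000 nM, in this assay.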

Compound 3, half-maximal inhibitory concentration: > 100000 nM
Compound 3: only a limit was reported; the forecaster's own chance of this, stated with the estimate: 90%; the middle value does not contradict the limit.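

Compound 3, like compound 1 and compound 2, returns only a limit in this assay, so the steps from compound 2 and from compound 1 to compound 3 cannot be read: the limit of > 100000 nM in this assay, at which 3 of the 3 values shown sit. The compounds shown leave open whether methyl or hydrogen on the aromatic carbon, or hydroxy or hydrogen on the saturated ring carbon, changes inhibition in this assay.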